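Anilino substitution on the shared core: hydrogen to methyl

The source may report more compounds than this note shows. Statements on the series, on what has been measured and on what is new or still open speak of the compounds shown alone.

Compound 3 `COc1cccc(/C=C/C(=O)c2sc(Nc3ccccc3)nc2C)c1` carries an unsubstituted anilino group on the shared core. In a functional assay on NCI-H460 cells (Homo sapiens) for cytotoxicity, read by MTT assay (on this read-out lower numbers stand for stronger inhibition and higher numbers for weaker inhibition), compound 3 reaches only the limit, > 25000 nM. Compound 1 `COc1cccc(/C=C/C(=O)c2sc(Nc3cccc(Cl)c3)nc2C)c1` and compound 2 `COc1cccc(/C=C/C(=O)c2sc(Nc3ccc(Cl)cc3)nc2C)c1` carry 3-chlorophenyl and 4-chlorophenyl groups on the same nitrogen. In this assay compound 1 likewise gives only the limit, > 25000 nM. In this assay compound 2 also gives only the limit, > 25000 nM. The steps a step that the two limits leave unreadable from compound 1 to compound 2, a step that the two limits leave unreadable from compound 1 to compound 3 and a step that the two limits leave unreadable from compound 2 to compound 3 therefore cannot be sized, because of the limit of > 25000 nM in this assay, at which 3 of the 3 values shown sit.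

Compound 4 `COc1cccc(/C=C/C(=O)c2sc(Nc3ccc(C)cc3)nc2C)c1` differs from compound 3 by methyl in place of hydrogen on an aromatic carbon; cut one bond further out, the change reads phenyl to 4-methylphenyl, or anilino to (4-methylphenyl)amino. Among the compounds with values here, no measured step shows a substituent on this ring moving the read-out off the limit, so no step beyond the scatter is expected in this assay, in either direction. Compound 4 is estimated at 35000 nM, within 12000 nM to 100000 nM. The expected step that the limit leaves unreadable from compound 3 to compound 4 is most likely to be reported as a limit again.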

Compound 4, half-maximal inhibitory concentration: > 25000 nM
Compound 4: a limit, no number (the forecaster's own chance of this, stated with the estimate: 80%); the middle value does not contradict the limit.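

No new step can be read from compound 4 to compound 1, compound 2 or compound 3, because all four compounds share one limit: the limit of > 25000 nM in this assay, at which 4 of the 4 values shown sit.

The compounds shown leave open how their anilino groups rank in this assay, and whether any substituent on that ring gives a measurable value.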